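Trifluoromethyl in Place of Methyl: Expected Cytotoxicity of Compound 4

The source may hold more compounds than are shown below. What is called first, only, known or untested is meant among the compounds shown, and "the series" means these compounds.

Compound 1 `Cc1cccc(-c2nc3ccc(C)cc3c(=O)[nH]2)c1` gives in a functional assay on HeLa cells (Homo sapiens) for cytotoxicity, read by MTT assay, with a stated time of 2 days (on this read-out lower numbers stand for stronger inhibition and higher numbers for weaker inhibition), only a limit, > 50000 nM.
Compound 2 `Cc1ccc2nc(-c3ccccc3C(F)(F)F)[nH]c(=O)c2c1` gives in this assay 2450 nM.
Compound 3 `Cc1ccc2nc(-c3ccccc3C)[nH]c(=O)c2c1` gives in this assay 4580 nM.

Compound 2 arises from compound 3 by trifluoromethyl in place of methyl on an aromatic carbon, and the result was a 1.9-fold lower number from compound 3 to compound 2 (0.27 log units; within the scatter). Compound 4 `Cc1ccc2nc(-c3cccc(C(F)(F)F)c3)[nH]c(=O)c2c1` has not yet been measured in this assay. It arises from compound 1 by trifluoromethyl in place of methyl on an aromatic carbon, the same kind of change, though here the place is meta to a large group where in compound 2 it is ortho to a large group. The difference between the core of compound 1 and the core of compound 3 is not broken down here. Compound 1 is expected to give a poor anchor because the limit of > 50000 nM in this assay, at which 1 of the 3 values shown sits, leaves its value as a limit only. Since the earlier step stayed within the scatter, the expected step is a step that the limit leaves unreadable from compound 1 to compound 4. Compound 4 is therefore expected to give about 60000 nM, most likely again as a limit, between 20000 nM and 200000 nM.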

Compound 4, half-maximal inhibitory concentration: > 50000 nM
Compound 4: no number, only a limit; the forecaster's own chance of this, stated with the estimate: 65%; the middle value does not contradict the limit.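

In this assay, compound 1 and compound 4 both stand only as limits, so no step between them can be read: the limit of > 50000 nM in this assay, at which 2 of the 4 values shown sit.

The compounds shown leave open whether trifluoromethyl in place of methyl changes the read-out when meta to a large group.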